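Bromo on the thiophene ketone: expectation before measurement

The source may report more compounds than this note shows. Statements on the series, on what has been measured and on what is new or still open speak of the compounds shown alone.

Measured so far in a functional assay on MDA-MB-231 cells (Homo sapiens) for antiproliferative activity, read by XTT assay, with a stated time of 72 h; on this read-out lower numbers stand for stronger inhibition and higher numbers for weaker inhibition:
- compound 1 `COc1ccc(-c2cc3ccccc3nc2/C=C/C(=O)c2c(OC)cccc2OC)cc1`: compound 1 gives 5630 nM
- compound 2 `COc1ccc(-c2cc3ccccc3nc2/C=C/C(=O)c2cccs2)cc1`: compound 2 gives 410 nM

Compound 2 holds the lowest of the two numbers; the only other, compound 1, stands a step above it, a 14-fold lower number from compound 1 to compound 2 (1.14 log units; beyond the scatter), a large and clear difference. Among the compounds with values here, only this one step exists, and it concerns the whole aryl group on the carbonyl carbon, not a substituent on the thiophen-2-yl ring.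

Compound 3 `COc1ccc(-c2cc3ccccc3nc2/C=C/C(=O)c2ccc(Br)s2)cc1` differs from compound 2 by bromo in place of hydrogen on an aromatic carbon. Within the data shown here, no measured pair shows a hydrogen-to-bromo exchange, so the single step from compound 1 to compound 2 bears on it only in that the thiophen-2-yl ketone is the better of the two carbonyl partners and compound 3 keeps it. Nothing in the data tells which way a bromo here moves the number; the expectation is therefore no step beyond the scatter, a 1.0-fold lower number from compound 2 to compound 3 (0.01 log units; within the scatter), with a wide range to either side.

Compound 3 is estimated at 400 nM, between 120 nM and 1400 nM.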

Compound 3, half-maximal inhibitory concentration: < 100 nM
Compound 3: a limit, no number (the forecaster's own chance of this, stated with the estimate: 3%); middle value at least 4.0-fold (0.60 log units) away from the limit.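

In this assay compound 3 stands at a limit of the assay, not at a number: the limit of < 100 nM in this assay, at which 1 of the 3 values shown sits. The earlier compounds shown here changed only the whole aryl group on the carbonyl carbon, whereas here the thiophen-2-yl ring itself carries a new substituent, and bromo in place of hydrogen on the aromatic carbon next to the ring sulfur gives an at least 4.1-fold lower number from compound 2 to compound 3 (0.61 log units; beyond the scatter), so a single heavy atom at this place moves the read-out beyond the scatter towards stronger inhibition. The 5-bromothiophen-2-yl group in place of 2,6-dimethoxyphenyl on the carbonyl carbon gives an at least 56-fold lower number from compound 1 to compound 3 (1.75 log units; beyond the scatter), which makes this position, two ring bonds from the ring atom bearing the large group, a site where the series gains rather than loses.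

From the compounds shown here alone, the full size of both steps stays open, as each is printed only as a minimum. Whether the gain is particular to bromo also stays open, since the compounds shown do not tell how chloro, methyl, methoxy or an amine at the same carbon would read, or how bromo would read on another carbon of the thiophene ring.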